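This account rests on a few compounds, and the source may have more. Where it says the series, first, only, none or still open, it means among the compounds named here.

Measured in an ADME assay on HEp-2 cells (Homo sapiens) for cytotoxicity; a lower number here means that less compound is tolerated, a higher number that more compound is tolerated:
- compound 1 `CC(C)CCn1c(Cn2c(=O)n(C(C)C)c3ccccc32)nc2cc(CN(C)C)ccc21`: 5650 nM
- compound 2 `CC(C)CCn1c(Cn2c(=O)n(C(C)C)c3ccccc32)nc2cc(C(C)(C)N)ccc21`: 3270 nM
- compound 3 `C=C(C)n1c(=O)n(Cc2nc3cc(C(C)=O)ccc3n2CCC(C)C)c2ccccc21`: 740 nM

Compound 2 lies within the scatter of compound 1 and well apart from compound 3, which has the lowest number of the three. Compound 4 `CC(C)CCn1c(Cn2c(=O)n(C(C)C)c3ccccc32)nc2cc(-c3nn[nH]n3)ccc21` carries 2H-tetrazol-5-yl in place of 1-amino-1-methylethyl on an aromatic carbon. Going by the values given here, only one measured step bears on this place: a 1.7-fold lower number from compound 1 to compound 2 (0.24 log units; within the scatter). It is small, but it does not involve the incoming group. Among the compounds with values here, compound 3 differs from compound 2 in more than one place, so it gives no clean step. No change beyond the scatter is therefore expected in this assay, in either direction, though the uncertainty is wide. The expected step is a 1.4-fold higher number from compound 2 to compound 4 (0.14 log units; within the scatter). Compound 4 is estimated at 4500 nM, with an expected range from 1500 nM to 15000 nM.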

Compound 4, half-maximal cytotoxic concentration: 2000 nM
Beside the measured number, compound 4's estimate is 2.3-fold (0.35 log units) above it, within the range that was stated.
By their numbers in this assay, from the lowest: compound 3; then compounds 4, 2 and 1 (each within the scatter of the next, the first and the last beyond it).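

In this assay this aromatic carbon tolerates a five-membered aromatic ring with 4 hetero atoms about as well as 1-amino-1-methylethyl: the change gives a 1.6-fold lower number from compound 2 to compound 4 (0.21 log units; within the scatter) and stays within the scatter. Against (dimethylamino)methyl, the same ring gives a 2.8-fold lower number from compound 1 to compound 4 (0.45 log units; beyond the scatter) and is the first step at this position to pass beyond the scatter, though only modestly. Nothing shown here accounts for either step. As far as these compounds go, whether a carboxylic acid or a primary amide at this place would give a number close to that of compound 4 remains open.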